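Swapping a thiophene for an acetylphenyl on an imidazo core

The source may hold more compounds than are shown below. What is called first, only, known or untested is meant among the compounds shown, and "the series" means these compounds.

Measured so far:
compound 1 `COc1ccc(-c2cn3ccnc3c(-c3ccc4ncn(C5CCCCC5)c4c3)n2)cc1` gives 80%
compound 2 `c1cn2cc(-c3ccsc3)nc(-c3ccc4ncn(C5CCCCC5)c4c3)c2n1` gives 5.56%

In a functional assay on Hs-578T cells (Homo sapiens) for inhibition, read by sulforhodamine B assay, with a stated time of 48 h, tested at 10 uM (on this read-out lower numbers stand for less inhibition and higher numbers for more inhibition at the one concentration tested (going by the name of the read-out)), compound 2 stands lowest of the two numbers; the nearest is compound 1, which lies a number 74.4 percentage points lower from compound 1 to compound 2 (beyond the scatter) when read from compound 1 to compound 2. Compound 3 `CC(=O)c1ccc(-c2cn3ccnc3c(-c3ccc4ncn(C5CCCCC5)c4c3)n2)cc1` is not yet measured. Its change from compound 2 is 4-acetylphenyl in place of thiophen-3-yl on an aromatic carbon. For the measured compounds named here, the one step that bears on it, from compound 1 to compound 2, moved a six-membered carbon-only ring to thiophen-3-yl and fell far; the reverse move is now made, so a large rise is expected, a number 49.4 percentage points higher from compound 2 to compound 3 (beyond the scatter). Compound 3 is estimated at 55%, between 20% and 85%.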

Compound 3, a percentage reported as inhibition, at one concentration (the size of the read-out at that concentration, not a potency): 6.34%
The estimate for compound 3 lay 48.7 percentage points above the measured number; measured number outside the range, below it.
By their numbers in this assay, from the lowest: compounds 2 and 3 (each within the scatter of the next); then compound 1.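

In this assay, 4-acetylphenyl in place of thiophen-3-yl gives a number 0.8 percentage points higher from compound 2 to compound 3 (within the scatter) and so a six-membered carbon-only ring at this position does not by itself bring back the inhibition seen with compound 1. With that ring kept, acetyl in place of methoxy gives a number 73.7 percentage points lower from compound 1 to compound 3 (beyond the scatter) and so, across these compounds, the group carried on the ring matters as well as the ring. Nothing measured here explains this difference. Still open, from the compounds shown here alone, is how a hydroxyl, an amine or a carboxylic acid in place of the methoxy would read.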